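A few compounds are considered here, and "the series" means these few. Any claim that something is new, unique, unknown or untested is made for them only; others in the source may bear on it.

Compound 2 `O=C1C=C(Nc2cccc(F)c2)C(=O)c2c1nc1n2[C@H]2OC[C@@H](O)[C@H]2OC1` is one of three members of a shared core examined in a functional assay on MCF7 cells (Homo sapiens) for inhibition, read by sulforhodamine B assay; a lower number here means a stronger inhibitor, a higher number a weaker inhibitor. In this assay compound 2 gives 5500 nM. Compound 1 `CCc1ccc(NC2=CC(=O)c3c(nc4n3[C@H]3OC[C@@H](O)[C@H]3OC4)C2=O)cc1` gives 8990 nM in this assay, and the two numbers lie within the usual scatter of each other. Compound 3 `O=C1C(NCc2ccccc2)=CC(=O)c2c1nc1n2[C@H]2OC[C@@H](O)[C@H]2OC1` has only a limit of the assay in this assay, > 8000 nM. The step that the limit leaves unreadable from compound 1 to compound 3 thus cannot be read as a size; the limit of > 8000 nM in this assay, at which 1 of the 3 values shown sits, marks the limit at which compound 3 sits.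

Compound 4 `O=C1C=C(Nc2ccccc2)C(=O)c2c1nc1n2[C@H]2OC[C@@H](O)[C@H]2OC1` has not yet been measured. It differs from compound 2 by hydrogen in place of fluoro on an aromatic carbon. Within the data shown here, no measured step removes a fluoro from an aromatic ring, and the only step on record, from compound 1 to compound 3, concerns a different change and is unreadable. What the measured compounds do show is that compound 1 and compound 2, carrying different groups on the amine nitrogen, sit within scatter of each other. Compound 4 is therefore expected to show a step of a 1.1-fold higher number from compound 2 to compound 4 (0.04 log units; within the scatter) that stays within the scatter. The estimate for compound 4 in this assay is 6000 nM, with a range from 3000 nM to 12000 nM.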

Compound 4, half-maximal inhibitory concentration: > 4000 nM
Compound 4: only a limit was reported; the forecaster's own chance of this, stated with the estimate: 20%; the middle value is on the limit's open side.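

Compound 4 has only a limit in this assay and not a number, so the step from compound 2 to compound 4, hydrogen in place of fluoro on an aromatic carbon, cannot be read as a size: the limit of > 4000 nM in this assay, at which 1 of the 4 values shown sits.

Whether 3-fluorophenyl and phenyl differ in this assay on the shared core stays open with the compounds shown.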